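Phenyl added to the ring of compound 1

The source may hold more compounds than are shown below. What is called first, only, known or untested is meant among the compounds shown, and "the series" means these compounds.

Within the data shown here, in a functional assay on A549 cells (Homo sapiens) for inhibition, read by sulforhodamine B assay (on this read-out lower numbers stand for stronger inhibition and higher numbers for weaker inhibition), compound 1 `COC(=O)CC/C(C)=C/Cc1c(OC)c(C)c2c(c1OCC#CCN1CCCc3ccccc31)C(=O)OC2` gives 18000 nM, the lower of the two numbers so far, and compound 2 `COC(=O)CC/C(C)=C/Cc1c(OC)c(C)c2c(c1OCC#CCN1CCC(C(=O)OC)CC1)C(=O)OC2` gives 40500 nM. Compound 3 `COC(=O)CC/C(C)=C/Cc1c(OC)c(C)c2c(c1OCC#CCN1CCC(c3ccccc3)c3ccccc31)C(=O)OC2` keeps everything in compound 1 except for one change: phenyl in place of hydrogen on a saturated ring carbon. Among the measured compounds shown here, the one measured step, a 2.3-fold higher number from compound 1 to compound 2 (0.35 log units; beyond the scatter), replaces the whole 1,2,3,4-tetrahydroquinolin-1-yl group and is modest, so it offers only weak guidance. A similarly modest move towards lower numbers is expected, though its direction is uncertain. The expected step is a 1.3-fold lower number from compound 1 to compound 3 (0.11 log units; within the scatter). Compound 3 is estimated at 14000 nM, with an expected range of 6000 nM to 35000 nM.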

Compound 3, half-maximal inhibitory concentration: 7680 nM
Compound 3: middle estimate off by 1.8-fold (0.26 log units), on the high side, and the stated range covers the measured number.
By their numbers in this assay, from the lowest: compound 3; then compound 1; then compound 2.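

In this assay, phenyl in place of hydrogen on a saturated ring carbon, three ring bonds from the ring nitrogen, gives a 2.3-fold lower number from compound 1 to compound 3 (0.37 log units; beyond the scatter). This shows that the number can be lowered by adding to the 1,2,3,4-tetrahydroquinolin-1-yl group at this ring carbon, whereas the earlier step replaced that whole group and raised the number. No measurement given here explains the shift. The compounds shown leave open whether methyl, hydroxyl or an amine on the same ring carbon would move the number the same way.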